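A few compounds are considered here, and "the series" means these few. Any claim that something is new, unique, unknown or untested is made for them only; others in the source may bear on it.

Values in a functional assay on HeLa cells (Homo sapiens) for inhibition, with a stated time of 72 h; a lower number here means that less compound is needed, a higher number that more compound is needed for the effect:
- compound 1 `COc1cc(CNCc2ccncc2)ccc1OCc1ccccc1F`: 5100 nM
- compound 2 `COc1cc(CNCc2ccncc2)ccc1OCc1ccc(F)cc1`: 6400 nM
- compound 3 `COc1cc(CNCc2ccncc2)ccc1OCc1ccc(Cl)nc1`: 400 nM

Of these three, compound 3 has the lowest number, 400 nM. Both steps leading to it are large: a 13-fold lower number from compound 1 to compound 3 (1.11 log units; beyond the scatter), and a 16-fold lower number from compound 2 to compound 3 (1.20 log units; beyond the scatter). The exchange of 2-fluorophenyl for 4-fluorophenyl separates the other two compounds by much less: a 1.3-fold higher number from compound 1 to compound 2 (0.10 log units; within the scatter).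

The next comparison is with compound 4 `COc1cc(CNCc2ccncc2)ccc1OCc1ccc(Cl)cc1`, where 4-chlorophenyl stands in place of 6-chloropyridin-3-yl on a saturated chain carbon bound to an oxygen on an aromatic ring: 4-chlorophenyl in place of 6-chloropyridin-3-yl on a saturated chain carbon bound to an oxygen on an aromatic ring.

The two large steps bear most directly on this change, but each of them alters both the ring and its halogen. Compound 4 has the carbon-only ring of compound 1 and compound 2, while it keeps the chlorine of compound 3. For the measured compounds named here, no measured pair isolates either feature. Part of the large steps is therefore expected to be reversed, giving a higher number but not a full return to the fluorinated pair.

In this assay the expected change is a 5.0-fold higher number from compound 3 to compound 4 (0.70 log units; beyond the scatter). For compound 4 the estimated value is 2000 nM, with an expected range of 500 nM to 7000 nM.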

Compound 4, half-maximal effective concentration: 890 nM
Compound 4: the middle estimate sits 2.2-fold (0.35 log units) above what was measured; measured number inside the range.
By their numbers in this assay, from the lowest: compound 3; then compound 4; then compounds 1 and 2 (each within the scatter of the next).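

In this assay, for the compounds shown here, the pair of compound 3 and compound 4 separates the ring nitrogen from the chlorine for the first time: with the chlorine kept, 4-chlorophenyl in place of 6-chloropyridin-3-yl gives a modest change (a 2.2-fold higher number from compound 3 to compound 4 (0.35 log units; beyond the scatter)), and the nitrogen-containing ring retains the lowest number. On the carbon-only ring, chloro in place of fluoro gives a larger change (a 7.2-fold lower number from compound 2 to compound 4 (0.86 log units; beyond the scatter)), and 4-chlorophenyl in place of 2-fluorophenyl, which changes the halogen and where it sits, gives a similar result (a 5.7-fold lower number from compound 1 to compound 4 (0.76 log units; beyond the scatter)), so among these four compounds most of the distance between the fluorinated pair and compound 3 goes with the chlorine and the smaller part with the ring nitrogen. No independent measurement accounts for either contribution.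

As far as these compounds go, whether the result is specific to chlorine remains open, as 4-bromophenyl, 4-methylphenyl and unsubstituted phenyl would be needed at this place to test it. Also open, from the compounds shown here alone, is whether the ring nitrogen would give a similar change alongside fluorine, as in 6-fluoropyridin-3-yl.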